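Dimethylamino to diethylamino on the side chain: two cores

The compounds below may be only part of what the source reports. "The series", "measured", "known", "first", "only" and "open" are said of these compounds alone.

Compound 1 `CN(C)CCn1c(N)c(-c2nc3ccccc3[nH]2)c2nc(C#N)c(C#N)nc21` and compound 2 `CCN(CC)CCn1c(N)c(-c2nc3ccccc3[nH]2)c2nc(C#N)c(C#N)nc21` share one core; compound 3 `CN(C)CCCCn1c(N)c(-c2nc3ccccc3o2)c2nc(C#N)c(C#N)nc21` and compound 4 `CCN(CC)CCCCn1c(N)c(-c2nc3ccccc3o2)c2nc(C#N)c(C#N)nc21` share another. The difference between the two cores is not broken down here. In a functional assay on Raji cells (Homo sapiens) for antiproliferative activity, read by MTT assay, with a stated time of 48 h (on this read-out lower numbers stand for stronger inhibition and higher numbers for weaker inhibition), compound 1 gives 8320 nM, and compound 2 gives 8950 nM. The change from compound 1 to compound 2 diethylamino in place of dimethylamino on a saturated chain carbon, two bonds along the chain from an aromatic nitrogen gives a 1.1-fold higher number from compound 1 to compound 2 (0.03 log units; within the scatter). Compound 3 gives 9200 nM in this assay, which sits within the scatter of both compound 1 and compound 2.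

The change from compound 3 to compound 4 diethylamino in place of dimethylamino on a saturated chain carbon, four bonds along the chain from an aromatic nitrogen is the same kind of change, made on a saturated chain carbon four bonds along the chain from an aromatic nitrogen rather than two bonds along. Going by the values given here, with only the one earlier step as a guide, the expected step from compound 3 to compound 4 is a 1.1-fold higher number from compound 3 to compound 4 (0.03 log units; within the scatter) in this assay, resting on the flat outcome seen in a 1.1-fold higher number from compound 1 to compound 2 (0.03 log units; within the scatter). Compound 4 is thus estimated at 9800 nM in this assay, with an expected range from 5000 nM to 19000 nM.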

Compound 4, half-maximal inhibitory concentration: 2610 nM
The estimate for compound 4 lay 3.8-fold (0.57 log units) above the measured number; measured number outside the range, below it.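

In this assay diethylamino in place of dimethylamino on the core of compound 3 gives a 3.5-fold lower number from compound 3 to compound 4 (0.55 log units; beyond the scatter) and so does not repeat the flat outcome seen on the core of compound 1. The size of this change therefore does not carry over unchanged from one of these compounds' cores to the other: the same change on two cores in this assay, a 1.1-fold higher number (0.03 log units; within the scatter) from compound 1 to compound 2 and a 3.5-fold lower number (0.55 log units; beyond the scatter) from compound 3 to compound 4, 3.8-fold (0.58 log units) apart, beyond the scatter of two such steps

This does not show that the core alone sets the size of the step, since the change sits two bonds along the chain from an aromatic nitrogen in one pair and four bonds along in the other, and each core is represented by a single pair.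

Still open, on these data alone, is how the step behaves when core and chain are varied separately, for example with 2-(dimethylamino)ethyl and 2-(diethylamino)ethyl on the core of compound 3, or the longer chains on the core of compound 1. Also open, as far as these compounds go, is whether a cyclic amine such as pyrrolidine or morpholine in place of diethylamino would follow the same course on either core.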